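The source may hold more compounds than are shown below. What is called first, only, known or untested is meant among the compounds shown, and "the series" means these compounds.

Compound 1 `CCc1ccc2nc(NC(=O)C3CC3)sc2c1`, compound 2 `Cc1ccc2nc(NC(=O)C3CC3)sc2c1` and compound 3 `CC(C)C(=O)Nc1nc2ccc(Cl)cc2s1` were tested in an ADME assay on H9c2 cells (Rattus norvegicus) for cytotoxicity; on this read-out lower numbers stand for stronger inhibition and higher numbers for weaker inhibition. In this assay compound 1 reaches only the limit > 50000 nM, not a number. Compound 2 likewise reaches only the limit > 50000 nM. Compound 3 too gives only the limit > 50000 nM. The change from compound 2 to compound 1 is methyl in place of hydrogen on a saturated chain carbon bound to an aromatic carbon, and its step that the two limits leave unreadable from compound 2 to compound 1 cannot be read because of the limit of > 50000 nM in this assay, at which 3 of the 3 values shown sit. The difference between the cores of compound 2 and compound 3 is not broken down here. Compound 4 `CC(C)(C)C(=O)Nc1nc2ccc(Cl)cc2s1` differs from compound 3 by methyl in place of hydrogen on a saturated chain carbon bound to a carbonyl carbon and two saturated chain carbons, the same kind of change, though the place differs: a carbonyl carbon and two saturated chain carbons rather than an aromatic carbon. Since compound 3 sits at the limit, the step that the limit leaves unreadable from compound 3 to compound 4 is expected to remain unreadable, and compound 4 is estimated at 60000 nM.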

Compound 4, half-maximal inhibitory concentration: > 50000 nM
Compound 4 ended at the assay's limit; the forecaster's own chance of this, stated with the estimate: 90%; the middle value lies beyond the limit too.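

The step from compound 3 to compound 4 cannot be read, because both compounds give only a limit, not a number: the limit of > 50000 nM in this assay, at which 4 of the 4 values shown sit.
The compounds shown leave open whether any structural change here alters the result in this assay at all.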